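Pyridin-2-yl in Place of the Methylimidazole

The source may report more compounds than this note shows. Statements on the series, on what has been measured and on what is new or still open speak of the compounds shown alone.

Measured so far in a physicochemical assay for solubility, at pH 7.4; on this read-out higher numbers stand for higher solubility and lower numbers for lower solubility:
compound 1, `Cc1ccc(-c2c[nH]cn2)cc1NC(=O)c1ccc(OCc2ccccn2)cc1`, gives 90000 nM
compound 2, `Cc1cc(C)c(-c2cn(C)cn2)cc1NC(=O)c1ccc(OCc2ccccn2)cc1`, gives 8000 nM
compound 3, `Cc1ccc(-c2ncc[nH]2)c(C)c1NC(=O)c1ccc(OCc2ccccn2)cc1`, gives 69000 nM

Compound 2 stands lowest of the three, and its gaps to compound 1 and to compound 3 both exceed the scatter. Compound 4, `Cc1cc(C)c(-c2ccccn2)cc1NC(=O)c1ccc(OCc2ccccn2)cc1`, is not yet measured. It differs from compound 2 in one place: pyridin-2-yl in place of 1-methyl-1H-imidazol-4-yl on an aromatic carbon. Among the compounds with values here, no measured pair in this set shows that same change, so its effect is not known from these data. Given that compound 2 already gives 8000 nM, a small downward step is expected, of about a 1.3-fold lower number from compound 2 to compound 4 (0.12 log units; within the scatter), though a result within the scatter would not surprise. For compound 4 the estimated value in this assay is 6000 nM, with a range from 1500 nM to 25000 nM.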

Compound 4, solubility: < 1000 nM
Compound 4: only a limit was reported (the forecaster's own chance of this, stated with the estimate: 5%); middle value at least 6.0-fold (0.77 log units) from the limit.
By their numbers in this assay, from the lowest: compound 2; then compounds 3 and 1 (each within the scatter of the next). At a limit, below all of these: compound 4.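

In this assay, the change at this position, ortho to a methyl group and para to a methyl group, gives an at least 8.0-fold lower number from compound 2 to compound 4 (0.90 log units; beyond the scatter), so the read-out is not indifferent to which of these two aromatic rings sits there. Compound 4 gives < 1000 nM, which is a limit of the assay and not a number. The size of the step therefore has only a lower bound: the limit of < 1000 nM in this assay, at which 1 of the 4 values shown sits.

On these data alone, how far compound 4 lies under its limit stays open. So does what an amine or a carboxylic acid on the pyridin-2-yl would do to the read-out.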